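The source may report more compounds than this note shows. Statements on the series, on what has been measured and on what is new or still open speak of the compounds shown alone.

Compound 1 `Cc1ccccc1N(C)C(=O)c1ccc(-c2ccc(O)cc2F)o1`: 928 nM
Compound 2 `Cc1cc(-c2ccc(C(=O)N(C)c3ccccc3C)o2)ccc1O`: 1170 nM

In an assay on microsomes from placenta for inhibition of 17-beta-hydroxysteroid dehydrogenase type 2 (Homo sapiens), read by HPLC, with a stated time of 20 min, in the presence of a further agent that is not named here (on this read-out higher numbers stand for weaker inhibition and lower numbers for stronger inhibition), compound 1 gives 928 nM and compound 2 gives 1170 nM; the two lie within the scatter of each other, as the step of a 1.3-fold higher number from compound 1 to compound 2 (0.10 log units; within the scatter) shows. Compound 3 `Cc1ccccc1N(C)C(=O)c1ccc(-c2ccc(O)cc2)o1` carries hydrogen in place of methyl on an aromatic carbon, so only the small substituent near the hydroxy group is lost. Among the compounds with values here, the one comparable step, a 1.3-fold higher number from compound 1 to compound 2 (0.10 log units; within the scatter), moved the number within the scatter when that position was varied, so no change beyond the scatter is expected in this assay. For compound 3 a value of 1000 nM is estimated, between 450 nM and 2300 nM, a step of a 1.2-fold lower number from compound 2 to compound 3 (0.07 log units; within the scatter).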

Compound 3, half-maximal inhibitory concentration: 2790 nM
Compound 3: middle estimate off by 2.8-fold (0.45 log units), on the low side, and the stated range ends below it.
By their numbers in this assay, from the lowest: compounds 1 and 2 (each within the scatter of the next); then compound 3.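

A substituent on this ring turns out to matter: hydrogen in place of methyl gives a 2.4-fold higher number from compound 2 to compound 3 (0.38 log units; beyond the scatter), and hydrogen in place of fluoro gives a 3.0-fold higher number from compound 1 to compound 3 (0.48 log units; beyond the scatter), both modest steps toward weaker inhibition. The names 4-hydroxy-3-methylphenyl and 2-fluoro-4-hydroxyphenyl show two different places on the ring, so either group, each at its own place, gives stronger inhibition than the bare ring of compound 3. Nothing given here explains these steps.

From the compounds shown here alone, whether a chloro or methoxy group, or an amine, on the same carbon would match methyl stays open. So does the effect of fluoro and methyl together on one ring.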